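Swapping the sulfonyl substituent on a shared piperazine core

The compounds below may be only part of what the source reports. "The series", "measured", "known", "first", "only" and "open" are said of these compounds alone.

Of the compounds shown here, three sharing one core have been measured in a functional assay on CHO-K1 cells for agonist activity at Glucose-dependent insulinotropic receptor (Homo sapiens), read by a luciferase reporter, with a stated time of 5 h; a higher number here means that more compound is needed for the effect, a lower number that less compound is needed. Compound 1 `CC(C)OC(=O)N1CCC(COc2ccc(N3CCN(C(=O)c4ccco4)CC3)nc2)CC1` gives 1900 nM, compound 2 `CCS(=O)(=O)N1CCN(c2ccc(OCC3CCN(C(=O)OC(C)C)CC3)cn2)CC1` gives 1300 nM, and compound 3 `CC(C)OC(=O)N1CCC(COc2ccc(N3CCN(S(=O)(=O)c4cccnc4)CC3)nc2)CC1` gives 2000 nM. Compound 3 has the highest number of the three, but the steps to both others stay within the scatter: a 1.1-fold higher number from compound 1 to compound 3 (0.02 log units; within the scatter), and a 1.5-fold higher number from compound 2 to compound 3 (0.19 log units; within the scatter). The other change on this ring nitrogen, a 1.5-fold lower number from compound 1 to compound 2 (0.16 log units; within the scatter), is likewise within the scatter.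

Compound 4 `CC(C)OC(=O)N1CCC(COc2ccc(N3CCN(S(=O)(=O)N4CCCCC4)CC3)nc2)CC1` differs from compound 3 in one place: piperidin-1-yl in place of pyridin-3-yl on a sulfonyl sulfur. The step that bears most directly on this change is the earlier swap on the same sulfonyl sulfur, a 1.5-fold higher number from compound 2 to compound 3 (0.19 log units; within the scatter), which did not move the number beyond the scatter; the exchange of the whole group on the ring nitrogen, a 1.1-fold higher number from compound 1 to compound 3 (0.02 log units; within the scatter), was also flat. Nothing in these three compounds suggests that what is attached to the sulfonyl sulfur shifts the number in this assay by more than the scatter, so no step beyond the scatter is expected in either direction.

The estimated step is therefore no change at the digits printed from compound 3 to compound 4 (within the scatter). Compound 4 is expected to give about 2000 nM, within a range from 900 nM to 4500 nM.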

Compound 4, half-maximal effective concentration: 1000 nM
Estimate against measurement, compound 4: 2.0-fold (0.30 log units) above, within the range that was stated.
By their numbers in this assay, from the lowest: compounds 4, 2, 1 and 3 (each within the scatter of the next).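

In this assay, piperidin-1-yl, a non-aromatic ring, can stand on the sulfonyl sulfur in place of the aromatic pyridin-3-yl without the number leaving the scatter (a 2.0-fold lower number from compound 3 to compound 4 (0.30 log units; within the scatter)), so this position is now seen to accept a change of ring type as well as the earlier exchange of ethyl for pyridin-3-yl. Compared directly with ethyl on the same sulfur (a 1.3-fold lower number from compound 2 to compound 4 (0.11 log units; within the scatter)) and with the (furan-2-yl)carbonyl group on the ring nitrogen (a 1.9-fold lower number from compound 1 to compound 4 (0.28 log units; within the scatter)), the (piperidin-1-yl)sulfonyl group also stays within the scatter, which means that all four compounds remain inseparable in this assay and none of these groups can be singled out. No independent data are available that would explain these numbers.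

On these data alone, whether any group on the sulfonyl sulfur can produce a step beyond the scatter remains open, for instance an amine, a carboxylic acid or a longer chain. As far as these compounds go, it is also open whether the same flat picture would hold if the rest of the shared core were changed.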